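The compounds below may be only part of what the source reports. "The series", "measured", "known", "first", "only" and "open" are said of these compounds alone.

In a functional assay on A549 cells (Homo sapiens) for antiproliferative activity, read by MTT assay, with a stated time of 72 h (a higher number here means a weaker inhibitor, a lower number a stronger inhibitor), compound 3 (`O=C(N/N=C/c1ccc(O)cc1)Nc1ccc(Oc2ccnc3[nH]ccc23)cc1`) gives 1910 nM as its half-maximal inhibitory concentration, and compound 1 (`O=C(N/N=C/c1ccc([N+](=O)[O-])cc1)Nc1ccc(Oc2ccnc3[nH]ccc23)cc1`) gives 2100 nM in the same test. These two numbers lie within the usual scatter of each other, so neither compound ranks ahead. Compound 2 (`O=C(N/N=C/c1cccc(Cl)c1Cl)Nc1ccc(Oc2ccnc3[nH]ccc23)cc1`), which carries chloro groups on the same ring, is recorded as "not active" (no number reported) with no number to compare.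

Compound 4 (`O=C(N/N=C/c1ccc(O)cc1Br)Nc1ccc(Oc2ccnc3[nH]ccc23)cc1`) differs from compound 3 in one place: bromo in place of hydrogen on an aromatic carbon is the change, with bromo in place of hydrogen on an aromatic carbon, ortho to a large group and meta to a hydroxy group. Thus 4-hydroxyphenyl becomes 2-bromo-4-hydroxyphenyl.

Among the compounds with values here, only one measured step touches this ring with a single number at each end, a 1.1-fold lower number from compound 1 to compound 3 (0.04 log units; within the scatter) when hydroxy replaces nitro, and it involves no halogen, so it offers only weak guidance. Within the data shown here, the one caution comes from compound 2 at "not active" (no number reported) as the only halogen-bearing compound tested, which leans the expectation slightly toward a higher number. The expected step is a 1.3-fold higher number from compound 3 to compound 4 (0.12 log units; within the scatter) and so no clear change. Compound 4 is expected at 2500 nM in this assay with an estimated range from 1000 nM to 7000 nM as its likely span.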

Compound 4, half-maximal inhibitory concentration: 5080 nM
Compound 4: middle estimate off by 2.0-fold (0.31 log units), on the low side; measured number inside the range.
By their numbers in this assay, from the lowest: compounds 3 and 1 (each within the scatter of the next); then compound 4.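

In this assay, placing a bromo group on an aromatic carbon, ortho to a large group and meta to a hydroxy group, gives a 2.7-fold higher number from compound 3 to compound 4 (0.42 log units; beyond the scatter), so this position on the ring responds to substitution, and a halogen here costs a modest amount of activity rather than abolishing it. The wider replacement of 4-nitrophenyl by 2-bromo-4-hydroxyphenyl gives a 2.4-fold higher number from compound 1 to compound 4 (0.38 log units; beyond the scatter), which also lies beyond the scatter, whereas exchanging nitro for hydroxy alone gave no measurable separation. No measurement shown here explains why the bromo group raises the number.

The compounds shown leave open whether this rise is specific to bromo or would also follow from a different group at the same position, such as fluoro, methyl or methoxy. They also leave open whether a bromo group at this position would have the same effect alongside a nitro group in place of the hydroxy group, and so whether the step carries over to other members of the series.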